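From Allyloxy to Cyclopropylmethoxy: One Further Step

The source may report more compounds than this note shows. Statements on the series, on what has been measured and on what is new or still open speak of the compounds shown alone.

Compound 1 `CCOC(=O)c1cnc(-c2ccccc2OCC)[nH]c1=O` gives 2 mg/kg.
Compound 2 `C=CCOc1ccccc1-c1ncc(C(=O)OCC)c(=O)[nH]1` gives 0.5 mg/kg.

In a functional assay on the whole organism (strain Sprague-Dawley) for inhibition, with Rattus norvegicus as the target, with a stated time of 10 min (a lower number here means that less compound is needed, a higher number that more compound is needed for the effect), compound 2, at 0.5 mg/kg, holds the lower of the two numbers. Compound 3 `CCOC(=O)c1cnc(-c2ccccc2OCC2CC2)[nH]c1=O` differs from it at one place: cyclopropyl in place of vinyl on a saturated chain carbon bound to an oxygen on an aromatic ring. Cyclopropyl thus stands in place of vinyl on a saturated chain carbon bound to an oxygen on an aromatic ring. Among the compounds with values here, only one measured step bears on this place, a modest one: a 4.0-fold lower number from compound 1 to compound 2 (0.60 log units; beyond the scatter). Within the data shown here, no measured compound yet carries a ring there, so no clear direction can be expected. The expected change is small, a 1.2-fold higher number from compound 2 to compound 3 (0.08 log units; within the scatter), and stays within the scatter. For compound 3 the estimated value is 0.6 mg/kg, with an expected range from 0.2 mg/kg to 2 mg/kg.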

Compound 3, dose for 50% inhibition: 0.3 mg/kg
Beside the measured number, compound 3's estimate is 2.0-fold (0.30 log units) above it; low and high end bracket the measured number.
By their numbers in this assay, from the lowest: compounds 3 and 2 (each within the scatter of the next); then compound 1.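

In this assay, the step of a 1.7-fold lower number from compound 2 to compound 3 (0.22 log units; within the scatter) lies within the scatter, so a ring at this place can stand in for vinyl with no readable difference. The step of a 6.7-fold lower number from compound 1 to compound 3 (0.82 log units; beyond the scatter) lies beyond the scatter, which shows that the double bond of the allyloxy group is not required for a number below that of the ethoxy group. Nothing measured here accounts for this result. The compounds shown leave open whether a larger ring such as cyclobutyl, a longer chain such as butyl, or an amine at this place would hold the number.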